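The source may report more compounds than this note shows. Statements on the series, on what has been measured and on what is new or still open speak of the compounds shown alone.

Measured so far:
Compound 1 `Cc1ccccc1NC(=O)NCC1(c2ccccc2)CCCCC1`: 640 nM
Compound 2 `Cc1cccc(NC(=O)NCC2(c3ccccc3)CCCCC2)c1`: 2800 nM

Among the measured compounds shown here, in an assay on microsomes from intestine for inhibition of acyl-CoA:cholesterol acyltransferase (Oryctolagus cuniculus) (on this read-out lower numbers stand for stronger inhibition and higher numbers for weaker inhibition), compound 2 gives the highest of the two numbers, and the only step towards it, a 4.4-fold higher number from compound 1 to compound 2 (0.64 log units; beyond the scatter), shows that moving the methyl on the phenyl attached to the urea nitrogen matters. Compound 3 `COc1ccc(NC(=O)NCC2(c3ccccc3)CCCCC2)cc1` carries 4-methoxyphenyl in place of 3-methylphenyl on an amide-type nitrogen. That measured step bears on this change only loosely, since a methoxy rather than a methyl now enters; its modest size suggests a modest step at most, with no clear direction. Compound 3 is therefore expected to show a 1.1-fold higher number from compound 2 to compound 3 (0.03 log units; within the scatter), giving an estimate of 3000 nM, within 800 nM to 12000 nM.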

Compound 3, half-maximal inhibitory concentration: 4900 nM
For compound 3 the middle estimate is 1.6-fold (0.21 log units) below the measured one; the measured number falls inside the stated range.
By their numbers in this assay, from the lowest: compound 1; then compounds 2 and 3 (each within the scatter of the next).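

In this assay there is a 1.8-fold higher number from compound 2 to compound 3 (0.24 log units; within the scatter) so 4-methoxyphenyl and 3-methylphenyl on this amide-type nitrogen cannot be told apart. By contrast, there is a 7.7-fold higher number from compound 1 to compound 3 (0.88 log units; beyond the scatter) so 2-methylphenyl gives the stronger inhibition against both other groups in this set. No measured evidence here explains these steps. Compound 3 changes both the group and its place on the ring, so the two contributions cannot be separated. As far as these compounds go, how a chlorine or an amine on this ring would read also remains open.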